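The source may hold more compounds than are shown below. What is called first, only, known or untested is meant among the compounds shown, and "the series" means these compounds.

Measured so far:
Compound 1 `Nc1[nH]c(C(=O)c2ccccc2)c(-c2cccc3ccccc23)c1C(=O)c1ccc(Cl)c(Cl)c1`: in an assay for inhibition of Polyunsaturated fatty acid lipoxygenase ALOX15 (Homo sapiens), with a stated time of 10 min (a lower number here means a stronger inhibitor, a higher number a weaker inhibitor), compound 1 gives only a limit, > 100000 nM.
Compound 2 `Nc1[nH]c(C(=O)c2ccccc2)c(-c2cccnc2)c1C(=O)c1cccc(Cl)c1`: in this assay compound 2 likewise gives only a limit, > 100000 nM.
Compound 3 `CCOC(=O)c1ccc(N)[nH]1`: in this assay compound 3 also gives only a limit, > 100000 nM.

Among the measured compounds shown here, compound 2 therefore stands nowhere distinct within the set: each value so far is a limit rather than a number, all three sitting at the limit of > 100000 nM in this assay, at which 3 of the 3 values shown sit, so no step between measured compounds can be drawn. Compound 4 `Nc1[nH]c(C(=O)c2ccccc2)c(-c2cccc(Cl)c2)c1C(=O)c1cccc(Cl)c1` differs from compound 2 by 3-chlorophenyl in place of pyridin-3-yl on an aromatic carbon. With nothing measured beyond the limit in this assay, no step beyond the scatter is expected in either direction. Compound 4 is expected to give 100000 nM (range 30000 nM to 300000 nM), an estimated step of a number no higher from compound 2 to compound 4 (the limit leaves the size open), most probably again reported only as a limit.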

Compound 4, half-maximal inhibitory concentration: > 100000 nM
Compound 4 ended at the assay's limit (the forecaster's own chance of this, stated with the estimate: 80%); the middle value sits exactly at the limit.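

No step can be read from compound 2 to compound 4, as both results are limits rather than numbers: the limit of > 100000 nM in this assay, at which 4 of the 4 values shown sit.

From the compounds shown here alone, whether any change to the shared core gives a number rather than a limit in this assay remains open.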